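Aryl-linked acyl-resorcinol series: ester to chloro-acid

The source may hold more compounds than are shown below. What is called first, only, known or untested is meant among the compounds shown, and "the series" means these compounds.

Compound 1 `Cc1cc(C(=O)O)ccc1OCCCCOc1ccc(C(=O)CC(C)C)c(O)c1C` carries a 4-carboxyphenyl ether bearing a methyl group at one end of the four-carbon linker, and in an assay on HEK293 cells for positive allosteric modulation of metabotropic glutamate receptor 2 (Rattus norvegicus), read by thallium flux, with a stated time of 2.5 min (a higher number here means that more compound is needed for the effect, a lower number that less compound is needed), compound 1 gives 192 nM. Compound 2 `COC(=O)c1ccc(OCCCCOc2ccc(C(=O)CC(C)C)c(O)c2C)cc1` keeps the same linker and acyl-resorcinol end but presents a 4-(methoxycarbonyl)phenyl group instead; in this assay compound 2 gives "not determined" (no result reported), so compound 2 cannot be placed against compound 1 on the scale.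

Compound 3 `Cc1c(OCCCCOc2ccc(C(=O)O)cc2Cl)ccc(C(=O)CC(C)C)c1O` is the next member. It differs from compound 2 in one place: 4-carboxy-2-chlorophenyl in place of 4-(methoxycarbonyl)phenyl on an oxygen on a saturated carbon. Within the data shown here, no measured step connects a pair of compounds in this set, so the size of the change in this assay from compound 2 to compound 3 cannot be taken from data. The closest comparator is compound 1, which shares the free acid and the linker and differs only in the substituent on the aryl ring. Because compound 1 gives 192 nM, compound 3 is expected to land near it, at about 220 nM with a range of 70 nM to 700 nM.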

Compound 3, half-maximal effective concentration: 96 nM
Compound 3: the middle estimate sits 2.3-fold (0.36 log units) above what was measured; measured number inside the range.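

In this assay, among these compounds, chloro in place of methyl on an aromatic carbon gives a 2.0-fold lower number from compound 1 to compound 3 (0.30 log units; within the scatter) and is the only step that can be read so far; steps involving compound 2 cannot be read. For these two free acids, the aromatic carbon accepts either methyl or chloro with no difference beyond the usual scatter, and the 4-carboxy-2-chlorophenyl group retains activity on the same linker and shared core as compound 1. No supporting data bear on why the two substituents read alike.

With no number for compound 2, the compounds shown do not settle whether the carboxylic acid can give way to its methyl ester, an amide or a tetrazole at this end of the molecule. Also open, as far as these compounds go, are fluoro, bromo, methoxy or trifluoromethyl on the same aromatic carbon, a hydrogen there in place of methyl or chloro, and a longer or shorter chain as the linker.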